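Series notes: compound 4, methoxy in place of fluoro

This account rests on a few compounds, and the source may have more. Where it says the series, first, only, none or still open, it means among the compounds named here.

Compound 2 `CNC(=O)c1ccc(Oc2cccc(NC(=S)Nc3ccc(F)cc3)c2)nc1` gives 42500 nM in a functional assay on HepG2 cells (Homo sapiens) for antiproliferative activity, read by MTT assay (on this read-out higher numbers stand for weaker inhibition and lower numbers for stronger inhibition), and stands highest of the two numbers shown, with compound 3 `CNC(=O)c1ccc(Oc2cccc(NC(=S)Nc3ccc(F)c(C(F)(F)F)c3)c2)nc1` nearest at 20200 nM. Compound 1 `CNC(=O)c1ccc(Oc2cccc(NC(=S)Nc3ccc(C)c(C)c3)c2)nc1` reaches only the limit of > 100000 nM in this assay. Compound 4 `CNC(=O)c1ccc(Oc2cccc(NC(=S)Nc3ccc(OC)cc3)c2)nc1` differs from compound 2 by methoxy in place of fluoro on an aromatic carbon. Going by the values given here, no measured step covers a methoxy group. The two steps known so far, an at least 2.3-fold lower number from compound 1 to compound 2 (0.37 log units; beyond the scatter) and a 2.1-fold lower number from compound 2 to compound 3 (0.32 log units; beyond the scatter), were both modest, and both moved toward lower numbers. For the untested change to methoxy a step of similar size is expected in this assay, its direction uncertain, with a slightly higher number judged somewhat more likely. Compound 4 is therefore estimated at 60000 nM, within 22000 nM to 160000 nM, which means an expected 1.4-fold higher number from compound 2 to compound 4 (0.15 log units; within the scatter).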

Compound 4, half-maximal inhibitory concentration: 85300 nM
The estimate for compound 4 lay 1.4-fold (0.15 log units) below the measured number; low and high end bracket the measured number.
By their numbers in this assay, from the lowest: compound 3; then compounds 2 and 4 (each within the scatter of the next). At a limit, above all of these: compound 1.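

In this assay, going by these compounds alone, methoxy in place of fluoro on this aromatic carbon, para to a large group, gives a 2.0-fold higher number from compound 2 to compound 4 (0.30 log units; within the scatter), so the first change at this position leaves the two groups inside the scatter. The step for 4-methoxyphenyl in place of 3,4-dimethylphenyl reads an at least 1.1-fold lower number from compound 1 to compound 4 (0.06 log units; that floor lies within the scatter), which is only a floor and separates neither aryl group from the other. Compound 1 stands at a limit, not a number: the limit of > 100000 nM in this assay, at which 1 of the 4 values shown sits.

From the compounds shown here alone, how an amine or a carboxylic acid would read on this aromatic carbon stays open. So does whether a trifluoromethyl group added to the methoxy ring of compound 4 would repeat a 2.1-fold lower number from compound 2 to compound 3 (0.32 log units; beyond the scatter).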